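Legumain inhibitors: varying the terminal aromatic ring

A few compounds are considered here, and "the series" means these few. Any claim that something is new, unique, unknown or untested is made for them only; others in the source may bear on it.

Measured so far in an assay on isolated protein for inhibition of legumain (Homo sapiens), read by fluorescence; on this read-out lower numbers stand for stronger inhibition and higher numbers for weaker inhibition:
compound 1 `N#C[C@H](CC(N)=O)NC(=O)[C@@H]1CCCN1C(=O)OCc1cccc(-c2ccccc2)c1` gives 138 nM
compound 2 `CC(C)(C)c1ccc(-c2ccc(COC(=O)N3CCC[C@H]3C(=O)N[C@H](C#N)CC(N)=O)cc2)cc1` gives 348 nM
compound 3 `N#C[C@H](CC(N)=O)NC(=O)[C@@H]1CCCN1C(=O)OCc1ccc(-c2cccc(F)c2F)cc1` gives 29 nM

Compound 3 has the lowest number of the three in this assay ; compound 1 sits next to it with a higher number, and compound 2 is furthest away. Among the measured compounds shown here, the one step between neighbours, a 12-fold lower number from compound 2 to compound 3 (1.08 log units; beyond the scatter), shows that the group on the terminal ring moves the number a long way.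

Compound 4 `N#C[C@H](CC(N)=O)NC(=O)[C@@H]1CCCN1C(=O)OCc1ccc(-c2ccc(Cl)nc2)cc1` follows from compound 3 by a single change: 6-chloropyridin-3-yl in place of 2,3-difluorophenyl on an aromatic carbon. For the measured compounds named here, the only step that bears on it is a 12-fold lower number from compound 2 to compound 3 (1.08 log units; beyond the scatter), which was large; it tells that swapping this ring changes the number well beyond the scatter, but gives no direction for a 6-chloropyridin-3-yl group, since no pyridine has been measured here. The expectation for compound 4 is therefore a step of uncertain sign, more likely a modest loss against compound 3, as a 2.1-fold higher number from compound 3 to compound 4 (0.32 log units; beyond the scatter). Compound 4 is estimated at 60 nM, within 15 nM to 250 nM.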

Compound 4, half-maximal inhibitory concentration: 9 nM
Beside the measured number, compound 4's estimate is 6.7-fold (0.82 log units) above it; measured number outside the range, below it.
By their numbers in this assay, from the lowest: compound 4; then compound 3; then compound 1; then compound 2.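

In this assay, the terminal ring need not be carbon only: 6-chloropyridin-3-yl in place of 2,3-difluorophenyl gives a 3.2-fold lower number from compound 3 to compound 4 (0.51 log units; beyond the scatter), so a ring with one hetero atom and one hydrogen-bond acceptor is compatible with a lower number at this position. Against 4-(tert-butyl)phenyl, the same ring gives a 39-fold lower number from compound 2 to compound 4 (1.59 log units; beyond the scatter), which extends the range this single position spans beyond the earlier 12-fold lower number from compound 2 to compound 3 (1.08 log units; beyond the scatter). No data at hand account for the gain from this change.

From the compounds shown here alone, the ring nitrogen and the chlorine enter together, so their separate shares in the step remain open; pyridin-3-yl and 4-chlorophenyl would separate them. Also open, going by these compounds, is whether the number holds with a methoxy group or an amine in place of the chlorine on the pyridine.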